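This account rests on a few compounds, and the source may have more. Where it says the series, first, only, none or still open, it means among the compounds named here.

The measured compounds and their values in a functional assay on OVCAR-5 cells (Homo sapiens) for inhibition, read by sulforhodamine B assay, with a stated time of 48 h; a lower number here means a stronger inhibitor of growth, a higher number a weaker inhibitor of growth: compound 1 `O=C(Nc1cccc(-n2cc(-c3ccncc3)c(-c3ccc(Cl)c(O)c3)n2)c1)Nc1cccc(C(F)(F)F)c1` gives > 32500 nM, which is a limit of the assay and not a number. Compound 2 `O=C(Nc1cccc(-n2cc(-c3ccncc3)c(-c3ccc(Cl)c(O)c3)n2)c1)Nc1ccc(Cl)c(Cl)c1` gives > 32500 nM, again a limit. Compound 3 `COc1cc(-c2nn(-c3cccc(NC(=O)Nc4ccc(Cl)c(C(F)(F)F)c4)c3)cc2-c2ccncc2)ccc1Cl` gives 11000 nM.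

Compound 3 therefore stands as the only one of the three with a number in this assay; the other two values are limits. Among the measured compounds shown here, the single measured step, a step that the two limits leave unreadable from compound 1 to compound 2, runs between two limits and has no readable size, and it changes the aryl group on the amide-type nitrogen rather than the part altered here.

Compound 4 `O=C(Nc1cccc(-n2cc(-c3ccncc3)c(-c3ccc(Cl)c(O)c3)n2)c1)Nc1ccc(Cl)c(C(F)(F)F)c1` differs from compound 3 by hydrogen in place of methyl on an oxygen on an aromatic ring. For the measured compounds named here, no measured pair shows this exact change. What the data do offer is that compound 1, which carries the hydroxy group that compound 4 would carry, sits at the limit of > 32500 nM in this assay, at which 2 of the 3 values shown sit. Compound 2, with the same hydroxy group, sits there too. Both differ from compound 4 in the aryl group on the amide-type nitrogen, so the comparison is loose. Compound 4 is nonetheless expected to come out weaker, by a 2.0-fold higher number from compound 3 to compound 4 (0.30 log units; within the scatter) in this assay, with a fair chance that only a limit is reported. Compound 4 is estimated at 22000 nM, within 7000 nM to 70000 nM.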

Compound 4, concentration for total growth inhibition: 16200 nM
Beside the measured number, compound 4's estimate is 1.4-fold (0.13 log units) above it; the measured number falls inside the stated range.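

Among the compounds shown here, the first direct pair for this change, methoxy to hydroxy on the aromatic ring, gives a 1.5-fold higher number from compound 3 to compound 4 (0.17 log units; within the scatter) in this assay, so the hydroxy group alone does not bring this series to the limit seen with the earlier hydroxy compounds. With the hydroxy group kept, the aryl group on the amide-type nitrogen now has steps with a readable floor: an at least 2.0-fold lower number from compound 2 to compound 4 (0.30 log units; that floor lies within the scatter), for trifluoromethyl in place of chloro, and an at least 2.0-fold lower number from compound 1 to compound 4 (0.30 log units; that floor lies within the scatter), for chloro in place of hydrogen. Each of these two steps starts from a limit of the assay and not a number, and each floor stays within the scatter, so neither establishes a real gain, and the readable picture remains thin: the limit of > 32500 nM in this assay, at which 2 of the 4 values shown sit.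

The compounds shown leave open what an ethoxy group or an amine in place of the methoxy or hydroxy group would do in this assay. They also leave open whether the methoxy to hydroxy step would stay this small with a different aryl group on the amide-type nitrogen, or in any other cell line.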